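A few compounds are considered here, and "the series" means these few. Any claim that something is new, unique, unknown or untested is made for them only; others in the source may bear on it.

Measured so far:
compound 1, `N#CN/C(=N\C1CCCC1)Nc1cc(Cl)cc(Cl)c1`, 12000 nM
compound 2, `C[C@H](/N=C(\NC#N)Nc1cc(Cl)cc(Cl)c1)c1ccccc1`, 25000 nM
compound 3, `C[C@@H](/N=C(\NC#N)Nc1cc(C(F)(F)F)cc(C(F)(F)F)c1)C(C)(C)C`, 18000 nM

Of the compounds shown here, three have been tested in a functional assay on Beta-TC3 cells (Rattus norvegicus) with Beta-TC3 (Mus musculus) as the target, using a membrane potential dye; a higher number here means a weaker inhibitor, a lower number a stronger inhibitor. Compound 1 gives the lowest number of the three, but its distance from compound 3 lies within the usual scatter of this kind of measurement, so those two cannot be told apart on these numbers alone. Only compound 2 stands clearly apart from compound 1, with a number that is beyond the scatter. All three carry the same central unit, which can be seen in their structures, and differ in the groups hung on either side of it.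

Compound 4, `CC(C)CC/N=C(\NC#N)Nc1cc(Cl)cc(Cl)c1`, has not yet been measured. It differs from compound 1 in a single place: isopentyl in place of cyclopentyl on a double-bonded nitrogen. The ring is thus replaced by an open chain with the same count of carbon atoms. Among the measured compounds there is no pair that differs in this way, so nothing measured here shows how such a change plays out. The expectation is therefore cautious. The step of a 1.3-fold higher number from compound 1 to compound 4 (0.12 log units; within the scatter) is expected to be small, about the size of the scatter or only a little beyond it, in the direction of a somewhat higher number. Compound 4 is estimated at 16000 nM, with a range from 6000 nM to 45000 nM.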

Compound 4, half-maximal inhibitory concentration: 800 nM
The estimate for compound 4 lay 20-fold (1.30 log units) above the measured number; the whole stated range lies above it.
By their numbers in this assay, from the lowest: compound 4; then compounds 1, 3 and 2 (each within the scatter of the next, the first and the last beyond it).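

In this assay, isopentyl in place of cyclopentyl on a double-bonded nitrogen gives a 15-fold lower number from compound 1 to compound 4 (1.18 log units; beyond the scatter) and so is a large step, the only one of its kind among these compounds. Within the data shown here, this position therefore responds strongly to the form of the group it carries, something the earlier compounds, which offered no pair differing in one place, could not show. Both groups hold the same count of heavy atoms, all carbon, and neither has a hydrogen-bond donor or acceptor, so the difference that the structures show lies in ring against open chain, and no measurement here explains why the open chain gives the lower number.

On these data alone, it remains open whether a shorter chain such as butyl, a longer chain such as hexyl, or an unbranched pentyl chain would give a number as low as that of compound 4. This single pair also leaves open whether the same change would give a similar step on a compound carrying the trifluoromethyl groups of compound 3 instead of chlorine.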